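Moving the nitro group around the nitrophenyl ring of compound 2

The compounds below may be only part of what the source reports. "The series", "measured", "known", "first", "only" and "open" are said of these compounds alone.

This account follows a single change made to compound 2, `COc1cc(/C=C2\CCC/C(=C\c3cccc([N+](=O)[O-])c3)C2=O)cc(Br)c1OC`. In a functional assay on MDA-MB-231 cells (Homo sapiens) for cytotoxicity, read by MTT assay (on this read-out higher numbers stand for weaker inhibition and lower numbers for stronger inhibition), compound 2 gives 13.9 ug/mL, the highest of the three numbers in hand. Its nearest neighbour is compound 1, `COc1cc(/C=C2\CCC/C(=C\c3ccccc3[N+](=O)[O-])C2=O)cc(Br)c1OC`, which in this assay gives 8.99 ug/mL; the step of a 1.5-fold higher number from compound 1 to compound 2 (0.19 log units; within the scatter) lies within the scatter. Compound 3, `CCCCOc1c(Br)cc(/C=C2\CCC/C(=C\c3cccc([N+](=O)[O-])c3)C2=O)cc1OC`, gives 5.53 ug/mL in this assay, and the step of a 2.5-fold lower number from compound 2 to compound 3 (0.40 log units; beyond the scatter) is a modest one.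

Compound 4, `COc1cc(/C=C2\CCC/C(=C\c3ccc([N+](=O)[O-])cc3)C2=O)cc(Br)c1OC`, differs from compound 2 only in the nitrophenyl group: 4-nitrophenyl in place of 3-nitrophenyl on a double-bonded chain carbon bound to a double-bonded ring carbon. Among the compounds with values here, of the measured steps, only that from compound 1 to compound 2 bears on this change, since it too exchanges one nitrophenyl for another on the same chain carbon, and that step stayed within the scatter. The butyl step from compound 2 to compound 3 alters a different part of the molecule and says nothing about the nitrophenyl. A step of no more than the scatter is therefore expected for compound 4 in this assay, in no particular direction, so that the expected step is a 1.2-fold lower number from compound 2 to compound 4 (0.06 log units; within the scatter). For compound 4 the estimated value in this assay is 12 ug/mL, with a range from 6 ug/mL to 25 ug/mL.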

Compound 4, half-maximal inhibitory concentration: 8.71 ug/mL
The estimate for compound 4 lay 1.4-fold (0.14 log units) above the measured number; the range from low to high includes it.
By their numbers in this assay, from the lowest: compounds 3, 4, 1 and 2 (each within the scatter of the next, the first and the last beyond it).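

With compound 4 in hand, all three nitrophenyl groups have been seen on the same chain carbon in this assay, and the two new comparisons, a 1.6-fold lower number from compound 2 to compound 4 (0.20 log units; within the scatter) and a 1.0-fold lower number from compound 1 to compound 4 (0.01 log units; within the scatter), both stay within the scatter, as the earlier step of a 1.5-fold higher number from compound 1 to compound 2 (0.19 log units; within the scatter) did. Where the earlier compounds offered a single exchange of this kind, the set now covers 2-nitrophenyl, 3-nitrophenyl and 4-nitrophenyl, and no pair among them can be told apart in this read-out, so on this core the place of the nitro group on the ring shows no measurable effect. No measurement is available that would explain this lack of separation.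

The compounds shown leave open whether the nitro group matters at all at this position, since every one of them carries it, and a plain phenyl, or an amine or a nitrile on that ring in its place, could answer that. They also leave open whether the longer chain of compound 3, which gave a 2.5-fold lower number from compound 2 to compound 3 (0.40 log units; beyond the scatter) alongside 3-nitrophenyl, would do the same alongside 4-nitrophenyl or 2-nitrophenyl.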